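This account rests on a few compounds, and the source may have more. Where it says the series, first, only, none or still open, it means among the compounds named here.

Measured compounds:
- compound 1, `CC1(C)CC(=O)c2c(-c3ccc(F)cc3)cc(-c3ccccc3)nc2C1`: 11.1%
- compound 2, `Cc1ccc(C2=CC(c3ccccc3)C3=C(CC(C)(C)CC3=O)N2)cc1`: "not active" (no number reported)
- compound 3, `COc1ccc(C2=CC(c3ccccc3)C3=C(CC(C)(C)CC3=O)N2)cc1`: 8.34%

In an assay on isolated protein for inhibition of glucose-6-phosphatase catalytic subunit 1 (Homo sapiens), read by inositol phosphate accumulation, with a stated time of 30 min, tested at 100 uM (on this read-out higher numbers stand for more inhibition at the one concentration tested (going by the name of the read-out) and lower numbers for less inhibition), compound 1 gives 11.1% and compound 3 gives 8.34%. The gap between these two numbers lies within the usual scatter of repeated measurements, so neither compound can be placed above the other. Compound 2 is recorded in this assay only as "not active" (no number reported), with no number attached. Of the two compounds that carry a number, compound 1 holds the higher one, but that lead over compound 3 is too small to carry any meaning on its own.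

The unmeasured compound 4, `CC1(C)CC(=O)c2c(-c3ccc(Cl)cc3)cc(-c3ccccc3)nc2C1`, shares the core of compound 1 and differs from it in a single place: chloro in place of fluoro on an aromatic carbon. Going by the values given here, no step between two measured compounds carries this same change, so its size here has not been observed, and the expectation rests only on the modest number of compound 1. The expected step is a number 1.9 percentage points higher from compound 1 to compound 4 (within the scatter), which is to say nothing beyond the scatter in either direction. Compound 4 is estimated at 13%, within a range from 2% to 28%.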

Compound 4, a percentage reported as inhibition, at one concentration (the size of the read-out at that concentration, not a potency): 11.3%
Beside the measured number, compound 4's estimate is 1.7 percentage points above it, and the stated range covers the measured number.
By their numbers in this assay, from the lowest: compounds 3, 1 and 4 (each within the scatter of the next).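

In this assay, going by these compounds alone, chloro in place of fluoro gives a number 0.2 percentage points higher from compound 1 to compound 4 (within the scatter) and this is the first step that can be read between two compounds differing in one place. It shows that, on this aromatic carbon para to a large group, going from 4-fluorophenyl to 4-chlorophenyl does not move the read-out beyond the usual scatter, so this swap gives no sign of a real difference at the one concentration tested. Nothing available here bears on why the two compounds read so alike.

From the compounds shown here alone, only these two groups have been compared at this position, so it remains open whether a group of a different kind there, such as an amine, a carboxylic acid or a longer chain, would give a step beyond the scatter. It is also open whether the same change from fluoro to chloro would give a similarly small step on the core of compound 3, where no such pair is shown.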